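A Methoxy Group Added to a Fluorinated Lactam Amidine

The source may hold more compounds than are shown below. What is called first, only, known or untested is meant among the compounds shown, and "the series" means these compounds.

Two amidines sharing one core have been measured so far. Compound 1 `COc1ccc(CNC(=N)[C@@H]2CCC(=O)N2Cc2ccccc2)cc1` gives 19.5% in a functional assay on SH-SY5Y cells (Homo sapiens) for cytotoxicity, read by MTT assay, with stated times of 8 h, 30 min and 12 h, tested at 5 uM; on this read-out higher numbers stand for a stronger effect at the one concentration tested and lower numbers for a weaker effect. Compound 2 `N=C(NCc1ccccc1)[C@@H]1CCC(=O)N1Cc1ccc(F)cc1` gives 31.4% in this assay, the higher of the two numbers, and its gap to compound 1 lies beyond the usual scatter. Since these two compounds differ in more than one place, their values alone do not isolate either change.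

Compound 3 `COc1ccc(CNC(=N)[C@@H]2CCC(=O)N2Cc2ccc(F)cc2)cc1` is yet to be measured. It differs from compound 2 by methoxy in place of hydrogen on an aromatic carbon. The entering group is also present in compound 1, whose value of 19.5% is the lower of the two, but that comparison is confounded by a second difference. In this assay the expected step is small and downward, within the scatter, so a number 6.4 percentage points lower from compound 2 to compound 3 (within the scatter) is estimated. Compound 3 is therefore expected to give about 25%, in a range from 12% to 38%.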

Compound 3, a percentage reported as activity, at one concentration (the size of the read-out at that concentration, not a potency): 38.1%
Beside the measured number, compound 3's estimate is 13.1 percentage points below it, and the stated range ends below it.
By their numbers in this assay, from the lowest: compound 1; then compounds 2 and 3 (each within the scatter of the next).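

Among these compounds, with compound 3, the methoxy change can be read on its own for the first time: in this assay, going from phenyl to 4-methoxyphenyl, para to a large group, gives a number 6.7 percentage points higher from compound 2 to compound 3 (within the scatter), so on this fluorinated compound the change cannot be told apart from the scatter. Among the compounds shown here, the fluoro change can now also be read with methoxy present on both sides, and fluoro in place of hydrogen on an aromatic carbon gives a number 18.6 percentage points higher from compound 1 to compound 3 (beyond the scatter), the only one of these two steps that clears the scatter. Nothing available explains either step.

The compounds shown leave open whether the fluoro step would hold without the methoxy group. They also leave open how a larger ether such as ethoxy, or an amine, would read at the methoxy position.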